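Compound 3 to compound 4: isopropyl to butyl on sulfur

The source may report more compounds than this note shows. Statements on the series, on what has been measured and on what is new or still open speak of the compounds shown alone.

Measured in an ADME assay on MT4 cells (Homo sapiens) for activation, read by MTT assay (a higher number here means that more compound is tolerated, a lower number that less compound is tolerated), each value a limit of the assay:
compound 1 `CCc1c(C(C)c2c(F)cccc2Cl)nc(SC(C)C)[nH]c1=O`: > 3000 nM
compound 2 `CCc1c(C(C)c2c(F)cccc2Cl)nc(SC2CCCC2)[nH]c1=O`: > 3000 nM
compound 3 `CCc1c(C(C)c2c(F)cccc2F)nc(SC(C)C)[nH]c1=O`: > 3000 nM

Compound 3 gives only a limit, > 3000 nM. No number has been read for any of the three compounds, the whole set resting on (the limit of > 3000 nM in this assay, at which 3 of the 3 values shown sit).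

Compound 4 `CCCCSc1nc(C(C)c2c(F)cccc2F)c(CC)c(=O)[nH]1` is still unmeasured and differs from compound 3 by butyl in place of isopropyl on a sulfur.

The closest measured change is cyclopentyl in place of isopropyl on a sulfur, which gave a step that the two limits leave unreadable from compound 1 to compound 2. Fluoro in place of chloro on an aromatic carbon gave a step that the two limits leave unreadable from compound 1 to compound 3 and bears less on this comparison, being a different kind of change. Among the measured compounds shown here, neither step has a size that can be carried over, so no step of known size or direction is expected in this assay. Another limit is the most likely report for the new compound. Should a number be read instead, the expected step is a step that the limit leaves unreadable from compound 3 to compound 4. For compound 4 the estimated value is 5000 nM. The estimated range for compound 4 runs from 2000 nM to 20000 nM.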

Compound 4, half-maximal cytotoxic concentration: > 3000 nM
Compound 4 was reported as a limit; the forecaster's own chance of this, stated with the estimate: 85%; the middle value is on the limit's open side.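

In this assay compound 4 gives > 3000 nM, a limit of the assay. Compound 3 also rests on a limit, so no step can be read between compound 3 and compound 4: the limit of > 3000 nM in this assay, at which 4 of the 4 values shown sit.

Open across compound 1, compound 2, compound 3 and compound 4: where any half-maximal cytotoxic concentration lies, and whether the groups on sulfur differ at all in this assay.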